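Indane in place of dihydrobenzofuran on a sulfonyl sulfur

The source may hold more compounds than are shown below. What is called first, only, known or untested is meant among the compounds shown, and "the series" means these compounds.

Compound 1: `CCN(C(=O)C1CCN(S(=O)(=O)c2ccc3occc3c2)CC1)[C@H](C)c1ccccc1` — 80%
Compound 2: `CCN(C(=O)C1CCN(S(=O)(=O)c2ccc3c(c2)CCO3)CC1)[C@H](C)c1ccccc1` — 88%

Within the data shown here, in a functional assay on CHO cells for positive allosteric modulation of muscarinic acetylcholine receptor M5 (Homo sapiens), read by calcium flux (on this read-out higher numbers stand for larger maximal responses and lower numbers for smaller maximal responses), compound 2 gives 88%, the higher of the two numbers so far, but compound 1 gives 80%, and the step of a number 8 percentage points higher from compound 1 to compound 2 (within the scatter) stays within the scatter, so the two compounds cannot be told apart on this read-out. Compound 3 is `CCN(C(=O)C1CCN(S(=O)(=O)c2ccc3c(c2)CCC3)CC1)[C@H](C)c1ccccc1`. It differs from compound 2 in one place: a group of 9 heavy atoms (9 carbon; one five-membered non-aromatic ring of carbon only, one six-membered aromatic ring of carbon only) in place of a group of 9 heavy atoms (8 carbon, 1 oxygen; one five-membered non-aromatic ring with 1 hetero atom, one six-membered aromatic ring of carbon only), on a sulfonyl sulfur. Among the measured compounds shown here, the one measured step bears on this only loosely: it also exchanged one fused bicyclic group for another of the same size on the same sulfonyl sulfur, and it produced no change beyond the scatter. For the measured compounds named here, nothing among the measured compounds shows what removing the single hydrogen-bond acceptor of the leaving group does. On this basis no shift beyond the scatter is expected for compound 3, and the expected step is a number 3 percentage points lower from compound 2 to compound 3 (within the scatter). Compound 3 is therefore estimated to give 85%, with a range from 70% to 100%.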

Compound 3, largest response reached (reported as percent of maximum), in percent of the reference or control that the assay uses: 97%
The estimate for compound 3 lay 12 percentage points below the measured number; measured number inside the range.
By their numbers in this assay, from the lowest: compounds 1, 2 and 3 (each within the scatter of the next, the first and the last beyond it).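

In this assay, 2,3-dihydro-1H-inden-5-yl on the sulfonyl sulfur, in place of the oxygen-containing group of compound 2, gives a number 9 percentage points higher from compound 2 to compound 3 (within the scatter), so losing the hydrogen-bond acceptor of that group brings no clear loss of maximal response. Set against the 1-benzofuran-5-yl group, the same 2,3-dihydro-1H-inden-5-yl group gives a number 17 percentage points higher from compound 1 to compound 3 (beyond the scatter), the first step at this position that clears the scatter, which shows that the maximal response can differ with the group placed here, even though compound 2 cannot be separated from either of the other two. That larger step changes the ring oxygen and the aromatic five-membered ring together, and no measurement here explains the numbers.

On these data alone, it remains open whether the oxygen or the aromatic five-membered ring matters more in that step, a question that a group such as 1H-inden-5-yl, carbon-only with a ring double bond, could help to answer. As far as these compounds go, how much room this position offers is also open: a plain phenyl, a larger 5,6,7,8-tetrahydronaphthalen-2-yl group, or an amine on the ring could each give a different maximal response.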